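This account rests on a few compounds, and the source may have more. Where it says the series, first, only, none or still open, it means among the compounds named here.

For the measured compounds named here, compound 1, `NC(=O)[C@@H]1CCCN1Cc1cc(=O)oc2cc(OCc3ccccc3)ccc12`, is one of two compounds measured in an assay for inhibition of Amine oxidase [flavin-containing] B (Rattus norvegicus) (on this read-out higher numbers stand for weaker inhibition and lower numbers for stronger inhibition), where compound 1 gives 380 nM. Going by the values given here, its only measured neighbour is compound 2, `NC(=O)[C@@H]1CCCN1Cc1cc(=O)oc2cc(OCc3cccc(F)c3)ccc12`, which in this assay gives 850 nM; the step of a 2.2-fold higher number from compound 1 to compound 2 (0.35 log units; beyond the scatter) comes from a fluoro in place of hydrogen on an aromatic carbon, and it leaves compound 1 with the lowest number of the two. Compound 3, `NCc1cc(=O)oc2cc(OCc3ccccc3)ccc12`, has not been measured; it differs from compound 1 by amino in place of 2-carbamoylpyrrolidin-1-yl on a saturated chain carbon bound to an aromatic carbon. Among the compounds with values here, the one measured step, a 2.2-fold higher number from compound 1 to compound 2 (0.35 log units; beyond the scatter), concerns a change at a different place and so says little about this larger change, which removes most of the side chain. Within the data shown here, with no directly comparable step to lean on, the estimate for compound 3 is a step of a 3.9-fold higher number from compound 1 to compound 3 (0.60 log units; beyond the scatter), expected to weaken inhibition and stated with a wide range. In this assay compound 3 is estimated at 1500 nM, expected to fall between 300 nM and 8000 nM.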

Compound 3, half-maximal inhibitory concentration: 21 nM
Compound 3: middle estimate off by 71-fold (1.85 log units), on the high side; the whole stated range lies above it.
By their numbers in this assay, from the lowest: compound 3; then compound 1; then compound 2.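

At this position, on a saturated chain carbon bound to an aromatic carbon, the large 2-carbamoylpyrrolidin-1-yl group with its ring and defined stereocentre is not required for inhibition in this assay, since replacing it with a plain amino gives an 18-fold lower number from compound 1 to compound 3 (1.26 log units; beyond the scatter) and a much lower number. The earlier fluoro change, a 2.2-fold higher number from compound 1 to compound 2 (0.35 log units; beyond the scatter), sits at a different place and is far smaller, so this position now stands out as the more sensitive of the two places examined. No measurement shown here explains why the smaller group gives the lower number.
The compounds shown leave open whether the carbamoyl group or the pyrrolidine ring accounts for the difference, which a plain pyrrolidin-1-yl group would help to separate. Going by these compounds, it also remains open how a methylamino group or a longer chain such as 2-aminoethyl would compare with amino here.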